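This account rests on a few compounds, and the source may have more. Where it says the series, first, only, none or still open, it means among the compounds named here.

In an ADME assay on cells (Fibroblast, Homo sapiens) for cytotoxicity, read by MTT assay, with a stated time of 24 h (on this read-out higher numbers stand for weaker inhibition and lower numbers for stronger inhibition), compound 1 `COc1ccc(N(CC(=O)NCCC[Te]c2ccccc2)C(=O)c2ccccc2)cc1` gives 7500 nM. Compound 2 `CC(C)(C)OC(=O)NCC(=O)OCC(=O)NCCC[Te]c1ccccc1` gives 19000 nM. Compound 3 `COc1ccc(N(CC(=O)NCCC[Se]c2ccccc2)C(=O)c2ccccc2)cc1` reaches only a limit of this assay, >= 100000 nM.

Compound 1 holds the lowest of the two numbers; its nearest neighbour is compound 2. Compound 3 sits at the limit of >= 100000 nM in this assay, at which 1 of the 3 values shown sits. Within the data shown here, the single measured step, an at least 13-fold higher number from compound 1 to compound 3 (1.12 log units; beyond the scatter), exchanges the chalcogen on the saturated chain and leaves the benzoyl end untouched.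

Compound 4 `COc1ccc(N(CC(=O)NCCC[Te]c2ccccc2)C(=O)/C=C/c2ccccc2)cc1` differs from compound 1 by 2-phenylethenyl in place of phenyl on a carbonyl carbon. Among the measured compounds shown here, no measured step touches that carbonyl position, so the change offers no guidance, and no step beyond the scatter is expected: no change at the digits printed from compound 1 to compound 4 (within the scatter). For compound 4 the estimate in this assay is 7500 nM, between 3000 nM and 20000 nM.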

Compound 4, half-maximal inhibitory concentration: 5000 nM
The estimate for compound 4 lay 1.5-fold (0.18 log units) above the measured number; measured number inside the range.
By their numbers in this assay, from the lowest: compounds 4 and 1 (each within the scatter of the next); then compound 2. At a limit, above all of these: compound 3.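

In this assay, among these compounds, the first measured change at this carbonyl position gives a 1.5-fold lower number from compound 1 to compound 4 (0.18 log units; within the scatter). The position therefore accepts 2-phenylethenyl in place of phenyl without a step beyond the scatter, unlike the chalcogen exchange on the saturated chain. Nothing measured here bears on why this swap leaves the number within the scatter. As far as these compounds go, whether an amine or a carboxylic acid on the 2-phenylethenyl group would shift the number remains open. So does whether exchanging tellurium for selenium would act on compound 4 as it did on compound 1.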